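Pyrazole in place of indazole on the aryl ether of compound 2

The source may report more compounds than this note shows. Statements on the series, on what has been measured and on what is new or still open speak of the compounds shown alone.

Three measured compounds share the core of compound 1 `CCCC(Nc1ccc(-n2cc(C(F)(F)F)cn2)nc1)c1ccc(C(=O)NCCC(=O)O)cc1`, which in an assay on cells for displacement of a labelled ligand from Glucagon receptor (Homo sapiens), in the presence of a further agent that is not named here (on this read-out lower numbers stand for stronger inhibition and higher numbers for weaker inhibition), gives 170 nM. Compound 2 `CCCC(Oc1ccc(-n2cc3ccccc3n2)cc1)c1ccc(C(=O)NCCC(=O)O)cc1` gives 290 nM in this assay, and compound 3 `CCCC(Nc1cc(C)c(-n2cc(C(F)(F)F)cn2)c(C)c1)c1ccc(C(=O)NCCC(=O)O)cc1` gives 12 nM in this assay. Compound 2 thus carries the highest of the three numbers; its gap to compound 1 lies within the scatter, while its gap to compound 3 lies well beyond it.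

Compound 4 `CCCC(Oc1ccc(-n2cc(C)cn2)cc1)c1ccc(C(=O)NCCC(=O)O)cc1` is not yet measured. Against compound 2 the change is 4-methyl-1H-pyrazol-1-yl in place of 2H-indazol-2-yl on an aromatic carbon. Among the compounds with values here, no step between measured compounds isolates this change, so the expectation rests only on the values shown. With compound 2 at 290 nM and compound 1, carrying a small pyrazole on a different ring, at 170 nM, the smaller group on compound 4 is expected to move the number little, at most a modest rise beyond the scatter, giving an estimated step of a 1.6-fold higher number from compound 2 to compound 4 (0.19 log units; within the scatter). For compound 4 the estimate in this assay is 450 nM, with a range from 130 nM to 1500 nM.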

Compound 4, inhibition constant: 1900 nM
Compound 4: middle estimate off by 4.2-fold (0.63 log units), on the low side; measured number above the stated range.
By their numbers in this assay, from the lowest: compound 3; then compounds 1 and 2 (each within the scatter of the next); then compound 4.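

In this assay, within the data shown here, this position, on an aromatic carbon para to a large group, is sensitive to the group it carries: 4-methyl-1H-pyrazol-1-yl in place of 2H-indazol-2-yl gives a 6.6-fold higher number from compound 2 to compound 4 (0.82 log units; beyond the scatter) and is the first single change that can be read. The counted differences are the heavy atoms, 9 leaving and 6 entering, and the six-membered aromatic ring of carbon only, while donor and acceptor counts stay the same. No evidence bears on why the number rises.

The compounds shown do not separate the part played by the methyl group from that of the lost ring. A 1H-pyrazol-1-yl group without the methyl, or a 1H-benzimidazol-1-yl group on the same aromatic carbon, would bear on that question.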